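A few compounds are considered here, and "the series" means these few. Any claim that something is new, unique, unknown or untested is made for them only; others in the source may bear on it.

In a functional assay on MCF7 cells (Homo sapiens) (a higher number here means a weaker inhibitor, a lower number a stronger inhibitor), compound 1 (`COc1cc(NC(C)CCCNC(=O)NCCO)c2ncccc2c1`) gives 25000 nM and compound 2 (`COc1cc(NC(C)CCCNC(=O)N(CCO)CCO)c2ncccc2c1`) gives 36000 nM. Within the data shown here, compound 2 thus stands level with compound 1, the only other measured compound. Among the measured compounds shown here, the one measured step is a 1.4-fold higher number from compound 1 to compound 2 (0.16 log units; within the scatter), with 2-hydroxyethyl in place of hydrogen on an amide-type nitrogen. Compound 3 (`COC(=O)NCCCC(C)Nc1cc(OC)cc2cccnc12`) differs from compound 2 in one place, with methoxy in place of bis(2-hydroxyethyl)amino on a carbonyl carbon. For the measured compounds named here, no measured compound carries methoxy there, so that single step offers only indirect guidance, and the present change is larger. With so little evidence, no shift beyond the scatter is expected in this assay, and either direction remains possible. The expected step is a 1.4-fold lower number from compound 2 to compound 3 (0.16 log units; within the scatter). For compound 3 the estimated value is 25000 nM, with an expected range of 9000 nM to 70000 nM.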

Compound 3, half-maximal inhibitory concentration: > 100000 nM
Compound 3: no number, only a limit; the forecaster's own chance of this, stated with the estimate: 15%; middle value at least 4.0-fold (0.60 log units) away from the limit.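

Compound 3 gives no number in this assay, only a limit: the limit of > 100000 nM in this assay, at which 1 of the 3 values shown sits. The carbonyl carbon, where the earlier pair stayed within the scatter, proves sensitive to the group it carries: methoxy in place of bis(2-hydroxyethyl)amino gives an at least 2.7-fold higher number from compound 2 to compound 3 (0.44 log units; beyond the scatter), and methoxy in place of (2-hydroxyethyl)amino gives an at least 4.0-fold higher number from compound 1 to compound 3 (0.60 log units; beyond the scatter). The earlier step therefore showed tolerance only between two amino groups on this carbonyl carbon, and it did not extend to methoxy in this assay.

From the compounds shown here alone, how far compound 3 lies past its limit stays unknown, so the full size of both steps is open. Also open, going by these compounds, is whether the shift follows from the methoxy oxygen or from the absence of the hydroxyethyl chains, a question that a plain amino or methylamino group on the same carbonyl carbon would address.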